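Replacing pyridin-2-yl with thiophen-3-yl on the shared core

The source may hold more compounds than are shown below. What is called first, only, known or untested is meant among the compounds shown, and "the series" means these compounds.

Three compounds share one core. Compound 1 `Oc1cccc(-c2cc(-c3ccc(Cl)cc3)nc(-c3cccs3)c2)c1` gives 15.1% in an assay on isolated protein for inhibition of DNA topoisomerase 1 (Homo sapiens), with a stated time of 30 min, tested at 100 uM; on this read-out lower numbers stand for a weaker effect and higher numbers for a stronger effect at the one concentration tested. Compound 2 `Oc1cccc(-c2cc(-c3ccc(Cl)cc3)nc(-c3ccco3)c2)c1` gives 27.1%, and compound 3 `Oc1cccc(-c2cc(-c3ccc(Cl)cc3)nc(-c3ccccn3)c2)c1` gives 30%, the largest of the three numbers, though its gap to compound 2 is within the scatter, as a number 2.9 percentage points higher from compound 2 to compound 3 (within the scatter) shows; only the gap to compound 1, a number 14.9 percentage points higher from compound 1 to compound 3 (beyond the scatter), lies beyond it. Compound 4 `Oc1cccc(-c2cc(-c3ccc(Cl)cc3)nc(-c3ccsc3)c2)c1` carries thiophen-3-yl in place of pyridin-2-yl on an aromatic carbon. The step that bears on this is the one from a thiophene to the pyridine, a number 14.9 percentage points higher from compound 1 to compound 3 (beyond the scatter), alongside a number 12 percentage points higher from compound 1 to compound 2 (beyond the scatter). Reversing toward a thiophene, a modest decrease in this assay is expected for compound 4, about a number 11 percentage points lower from compound 3 to compound 4 (beyond the scatter). Compound 4 is therefore estimated at 19%, ranging from 8% to 31%.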

Compound 4, a percentage reported as inhibition, at one concentration (the size of the read-out at that concentration, not a potency): 11.7%
For compound 4 the middle estimate is 7.3 percentage points above the measured one, and the stated range covers the measured number.
By their numbers in this assay, from the lowest: compounds 4 and 1 (each within the scatter of the next); then compounds 2 and 3 (each within the scatter of the next).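

In this assay the position does not separate the two thiophenes: thiophen-3-yl and thiophen-2-yl stand within the scatter of each other (a number 3.4 percentage points lower from compound 1 to compound 4 (within the scatter)). Thiophen-3-yl also falls short of both pyridin-2-yl (a number 18.3 percentage points lower from compound 3 to compound 4 (beyond the scatter)) and furan-2-yl (a number 15.4 percentage points lower from compound 2 to compound 4 (beyond the scatter)), so among these four compounds the low numbers go with the thiophene ring, whichever ring carbon carries it. Nothing available here explains this gap.

Going by these compounds, what a phenyl ring, pyridin-3-yl or an amine at this position would give in this assay stays open.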